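Replacing the Amide Aryl Group: Expected Potency of Compound 4

This account rests on a few compounds, and the source may have more. Where it says the series, first, only, none or still open, it means among the compounds named here.

Compound 1 `C=CC(=O)Nc1cccc(NC(=O)CSc2nc(Nc3ccccc3)c3ccccc3n2)c1` gives 8120 nM in a functional assay on NCI-H1975 cells (Homo sapiens) for inhibition, read by MTT assay, with a stated time of 72 h; a higher number here means a weaker inhibitor, a lower number a stronger inhibitor.
Compound 2 `O=C(CSc1nc(Nc2ccccc2)c2ccccc2n1)Nc1ccc([N+](=O)[O-])cc1` gives 13000 nM in this assay.
Compound 3 `CCc1ccc(NC(=O)CSc2nc(Nc3ccccc3)c3ccccc3n2)cc1` gives 9910 nM in this assay.

Compound 3 holds the second highest of the three numbers; the steps of a 1.2-fold higher number from compound 1 to compound 3 (0.09 log units; within the scatter) and a 1.3-fold lower number from compound 2 to compound 3 (0.12 log units; within the scatter) both lie within the scatter, so the three compounds are not separated by this measurement. Compound 4 `O=C(CSc1nc(Nc2ccccc2)c2ccccc2n1)Nc1ccc(Cl)c(Cl)c1` differs from compound 3 by 3,4-dichlorophenyl in place of 4-ethylphenyl on an amide-type nitrogen. Every measured step changes this same aryl group on the amide-type nitrogen: a 1.6-fold higher number from compound 1 to compound 2 (0.20 log units; within the scatter), a 1.2-fold higher number from compound 1 to compound 3 (0.09 log units; within the scatter) and a 1.3-fold lower number from compound 2 to compound 3 (0.12 log units; within the scatter), none of them beyond the scatter, even where a ring substituent was exchanged. No step beyond the scatter is therefore expected, a 1.0-fold lower number from compound 3 to compound 4 (0.02 log units; within the scatter). Compound 4 is estimated to give 9500 nM, with a range from 4000 nM to 25000 nM.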

Compound 4, half-maximal inhibitory concentration: 10400 nM
Estimate against measurement, compound 4: 1.1-fold (0.04 log units) below; the range from low to high includes it.
By their numbers in this assay, from the lowest: compounds 1, 3, 4 and 2 (each within the scatter of the next).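

Bringing in 3,4-dichlorophenyl puts chlorine on this aryl group on the amide-type nitrogen, and the number stays within the scatter of 4-ethylphenyl (a 1.0-fold higher number from compound 3 to compound 4 (0.02 log units; within the scatter)), 4-nitrophenyl (a 1.3-fold lower number from compound 2 to compound 4 (0.10 log units; within the scatter)) and 3-((vinylcarbonyl)amino)phenyl (a 1.3-fold higher number from compound 1 to compound 4 (0.11 log units; within the scatter)). All four aryl groups at this position therefore remain unseparated in this assay. Nothing available offers a reason for this.

Still open, from the compounds shown here alone, is whether an aryl ring carrying an amine or a carboxylic acid, or a longer alkyl chain in place of the ring, would move the number beyond the scatter. Going by these compounds, all four compounds keep the shared core, so the effect of changes there is also open.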